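The source may report more compounds than this note shows. Statements on the series, on what has been measured and on what is new or still open speak of the compounds shown alone.

Compound 1 `N#Cc1cnc(NCc2cnccc2C(F)(F)F)cc1N[C@H]1CC[C@@H](O)CC1` gives 100 nM in an assay on isolated protein for inhibition of protein kinase C theta type (Homo sapiens), read by TR-FRET, with a stated time of 2 h; a higher number here means a weaker inhibitor, a lower number a stronger inhibitor.
Compound 2 `N#Cc1cnc(NCc2cnccc2C(F)(F)F)cc1N[C@H]1CC[C@H](O)CC1` gives 350 nM in this assay.
Compound 3 `N#Cc1cnc(NCc2cnccc2C(F)(F)F)cc1NC[C@H]1CC[C@H](O)CC1` gives 50 nM in this assay.

Compound 3 has the lowest number of the three in this assay; compound 1 sits close to it, since the step of a 2.0-fold lower number from compound 1 to compound 3 (0.30 log units; within the scatter) stays within the scatter, while compound 2 lies further off, as shown by a 7.0-fold lower number from compound 2 to compound 3 (0.85 log units; beyond the scatter). Compound 4 `CO[C@H]1CC[C@H](CNc2cc(NCc3cnccc3C(F)(F)F)ncc2C#N)CC1` differs from compound 3 by methyl in place of hydrogen on an oxygen on a saturated carbon, turning the hydroxy into a methoxy. For the measured compounds named here, none of the measured steps touches that oxygen: one step, a 3.5-fold higher number from compound 1 to compound 2 (0.54 log units; beyond the scatter), concerns the configuration of the ring alone (the fact that compounds 1 and 2 differ only in the configuration as drawn), and the other two concern the link between ring and nitrogen. Going by the values given here, no measured step therefore speaks directly to this change, so compound 4 is expected to stay near compound 3, with a step of a 1.6-fold higher number from compound 3 to compound 4 (0.20 log units; within the scatter) in this assay. The estimate for compound 4 is 80 nM, expected to fall between 25 nM and 250 nM.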

Compound 4, half-maximal inhibitory concentration: 330 nM
Compound 4: the middle estimate sits 4.1-fold (0.62 log units) below what was measured; the whole stated range lies below it.
By their numbers in this assay, from the lowest: compounds 3 and 1 (each within the scatter of the next); then compounds 4 and 2 (each within the scatter of the next).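

On this ring the oxygen's hydrogen is not a neutral spot: methyl in its place gives a 6.6-fold higher number from compound 3 to compound 4 (0.82 log units; beyond the scatter). Against the compounds that carry a directly attached 4-hydroxycyclohexyl, the methoxy compound shows a 3.3-fold higher number from compound 1 to compound 4 (0.52 log units; beyond the scatter) and a 1.1-fold lower number from compound 2 to compound 4 (0.03 log units; within the scatter), so this one methyl removes the standing the hydroxy compound held. Nothing measured here explains why this change has this size. The compounds shown leave open whether an ethoxy group, or an amine in place of the hydroxy, would read like the methoxy or like the hydroxy.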